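Three Methoxy-Bearing Compounds and a Demethoxylated Analogue

The source may report more compounds than this note shows. Statements on the series, on what has been measured and on what is new or still open speak of the compounds shown alone.

Measured so far:
compound 1, `COc1ccc(CCCc2ccc(OC)cc2OC)c(O)c1`: 100%
compound 2, `COc1ccc(/C=C/C(=O)c2ccc(OC)c(OC)c2)cc1`: 97.2%
compound 3, `COc1ccc(/C=C/C(=O)c2ccc(OC)c(OC)c2)cc1OC`: 94%

In an ADME assay on RAW264.7 cells (Mus musculus) for cytotoxicity, read by MTT assay, with a stated time of 24 h, tested at 1.25 ug/mL (a higher number here means a weaker effect of the compound at the concentration tested, a lower number a stronger effect), compound 1 gives 100%, compound 2 gives 97.2% and compound 3 gives 94%. All three numbers lie within the scatter of one another, so none of the three can be called weaker or stronger than the others here.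

Compound 2 arises from compound 3 by one change, (hydrogen in place of methoxy on an aromatic carbon), and the step it made was a number 3.2 percentage points higher from compound 3 to compound 2 (within the scatter).

Compound 4, `COc1ccc(CCCc2ccc(OC)cc2O)cc1`, has not yet been measured. It arises from compound 1 by a change of the same kind, (hydrogen in place of methoxy on an aromatic carbon), though the surroundings differ: in compound 1 the place is ortho to a large group and meta to a methoxy group, whereas in compound 3 it is ortho to a methoxy group and meta to a large group. The difference between the core of compound 1 and that of compound 3 is not broken down here.

Because the earlier step was a number 3.2 percentage points higher from compound 3 to compound 2 (within the scatter), the step from compound 1 to compound 4 is expected to be a number 2 percentage points lower from compound 1 to compound 4 (within the scatter), small and within the scatter. Compound 4 is therefore estimated at 98%, between 90% and 104%.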

Compound 4, a percentage reported as activity, at one concentration (the size of the read-out at that concentration, not a potency): 98.9%
Estimate against measurement, compound 4: 0.9 percentage points below; the range from low to high includes it.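

In this assay, hydrogen in place of methoxy on an aromatic carbon of the core of compound 1 gave a number 1.1 percentage points lower from compound 1 to compound 4 (within the scatter). Set beside the same change on the other core, the two steps cannot be told apart: the same change on two cores in this assay, a number 3.2 percentage points higher (within the scatter) from compound 3 to compound 2 and a number 1.1 percentage points lower (within the scatter) from compound 1 to compound 4, 4.3 percentage points apart, within the scatter of two such steps. This shows that, on the two cores seen here, the change carries over as a step within the scatter, with no sign that the core alters its size; it does not show that the two places behave identically, since steps this small could hide a modest difference, and two pairs establish no rule for the series.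

The compounds shown leave open whether an amine or a carboxylic acid in that place on the core of compound 1 would give a step beyond the scatter. They also leave open how the same change reads at any other concentration.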